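Swapping a dichlorobenzyl for a fluorobenzyl on a diaminoquinoxaline core

A few compounds are considered here, and "the series" means these few. Any claim that something is new, unique, unknown or untested is made for them only; others in the source may bear on it.

Compound 1 `Nc1cc(N)c2nc(-c3ccccc3)c(NCc3ccc(Cl)c(Cl)c3)nc2c1`: 66100 nM
Compound 2 `COc1cc(CNc2nc3cc(N)cc(N)c3nc2-c2ccccc2)cc(OC)c1OC`: < 50200 nM
Compound 3 `CCOC(=O)[C@H](CCC(=O)O)NC(=O)c1ccc(Oc2nc3cc(N)cc(N)c3nc2-c2ccccc2)cc1`: < 100000 nM

Three compounds share a core with two amino groups and a phenyl ring, and all three were tested in a functional assay on COLO 205 cells (Homo sapiens) for inhibition, read by sulforhodamine B assay, with a stated time of 48 h; on this read-out lower numbers stand for higher toxicity in this test and higher numbers for lower toxicity in this test. Among the measured compounds shown here, compound 1 gives 66100 nM in this assay, the only plain number among the three. For compound 2 the result is a limit, < 50200 nM, at which one of the three values sits (the limit of < 50200 nM in this assay, at which 1 of the 3 values shown sits). For compound 3 the result is likewise a limit, < 100000 nM, also occupied by one of the three values (the limit of < 100000 nM in this assay, at which 1 of the 3 values shown sits). Compound 1 therefore stands as the single anchor against which a new compound can be judged.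

Compound 4 `Nc1cc(N)c2nc(-c3ccccc3)c(NCc3ccc(F)cc3)nc2c1` is not yet measured. It differs from compound 1 in one place: 4-fluorophenyl in place of 3,4-dichlorophenyl on a saturated chain carbon bound to a nitrogen on an aromatic ring. The two compounds are otherwise the same, so the comparison rests on the benzyl substituent alone. For the measured compounds named here, no step between two measured compounds of this set bears on such a change, and nothing here gives a measured property of either group. The expectation is therefore modest: a step of a 1.4-fold higher number from compound 1 to compound 4 (0.13 log units; within the scatter) that may lie within the usual scatter or slightly toward higher numbers. Compound 4 is expected to give about 90000 nM in this assay, within a range from 40000 nM to 200000 nM.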

Compound 4, concentration lethal to 50% of the cells: < 100000 nM
Compound 4: a limit, no number (the forecaster's own chance of this, stated with the estimate: 40%); the middle value does not contradict the limit.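

In this assay compound 4 gives < 100000 nM, which is a limit and not a number. The step from compound 1 to compound 4 therefore cannot be read: the limit of < 100000 nM in this assay, at which 2 of the 4 values shown sit.

The compounds shown leave open whether 4-fluorophenyl in place of 3,4-dichlorophenyl shifts this read-out at all, and if so in which direction.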